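Thioether Variation at the Purine Sulfur: Estimate for Compound 4

The source may hold more compounds than are shown below. What is called first, only, known or untested is meant among the compounds shown, and "the series" means these compounds.

Measured so far:
Compound 1 `Nc1ncnc2c1ncn2[C@@H]1O[C@H](COCCOCCNc2ncnc3c2ncn3[C@@H]2O[C@H](CO)[C@@H](O)[C@H]2O)[C@@H](O)[C@H]1O` gives 912000 nM in an assay on isolated protein for binding affinity to Equilibrative nucleoside transporter 1 (Homo sapiens); a higher number here means a weaker inhibitor, a lower number a stronger inhibitor.
Compound 2 `Cc1ccc(CSc2ncnc3c2ncn3[C@@H]2O[C@H](CO)[C@@H](O)[C@H]2O)cc1` gives 457 nM in this assay.
Compound 3 `Nc1nc(SI)c2ncn([C@@H]3O[C@H](CO)[C@@H](O)[C@H]3O)c2n1` gives 81300 nM in this assay.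

Compound 3 stands second highest of the three numbers. Its nearest neighbour is compound 1, whose value is higher by a margin beyond the scatter; its furthest is compound 2, whose value is lower by a much wider margin, also beyond the scatter. No two of the measured compounds differ in one place only, so no single step can be read off directly; the values are compared as they stand.

Compound 4 `CC(=O)c1cc(Cl)ccc1Sc1nc(N)nc2c1ncn2[C@@H]1O[C@H](CO)[C@@H](O)[C@H]1O` is the unmeasured member. It differs from compound 3 in one place: 2-acetyl-4-chlorophenyl in place of iodo on a sulfur. A thioether carrying a carbon substituent on the sulfur is also the feature of compound 2, the compound with the lowest number, whereas compound 3 carries only iodine there.

On this basis the step from compound 3 to compound 4 is expected to be a large one toward a lower number, a 54-fold lower number from compound 3 to compound 4 (1.73 log units; beyond the scatter), well beyond the scatter. Going by the values given here, compound 4 is therefore estimated at 1500 nM, with a range from 200 nM to 12000 nM, the wide range reflecting that no directly comparable pair exists among the measured compounds.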

Compound 4, half-maximal inhibitory concentration: 14500 nM
Estimate against measurement, compound 4: 9.7-fold (0.99 log units) below; measured number above the stated range.
By their numbers in this assay, from the lowest: compound 2; then compound 4; then compound 3; then compound 1.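

In this assay, going by these compounds alone, this is the first step that can be read at a single place: on a sulfur whose other neighbour is an aromatic carbon, 2-acetyl-4-chlorophenyl in place of iodo gives a 5.6-fold lower number from compound 3 to compound 4 (0.75 log units; beyond the scatter). The position therefore accepts a far larger group carrying a six-membered aromatic ring and a carbonyl without a rise in the number, although the gain is modest and compound 4 still reads 14500 nM in this assay. Nothing measured here accounts for the direction or the size of this step.

The compounds shown do not separate the share of the acetyl from that of the chloro substituent, nor do they show whether a plain phenyl, a benzyl or a ring bearing a carboxylic acid on the same sulfur would lower the number further. Within the data shown here, also open is whether the amine on the core shared by compound 3 and compound 4 alters the effect of a substituent on the sulfur, since no pair differs at that place alone.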